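Swapping the 4-hydroxyphenyl group on the weakest compound

The source may hold more compounds than are shown below. What is called first, only, known or untested is meant among the compounds shown, and "the series" means these compounds.

Measured in a functional assay on MCF7 cells (Homo sapiens) for inhibition, read by MTT assay, with a stated time of 72 h; a higher number here means a weaker inhibitor, a lower number a stronger inhibitor:
Compound 1 `Cc1ccc(-c2nnc(SCCCN3CCN(c4nc5ccccc5o4)CC3)o2)cc1`: 60400 nM
Compound 2 `Fc1ccc(-c2nnc(SCCCN3CCN(c4nc5ccccc5o4)CC3)o2)cc1`: 52300 nM
Compound 3 `Oc1ccc(-c2nnc(SCCCN3CCN(c4nc5ccccc5o4)CC3)o2)cc1`: 260000 nM

Compound 3, at 260000 nM, has the highest number of the three, which makes it the weakest inhibitor here. Compound 4 `O=C(NCc1nnc(SCCCN2CCN(c3nc4ccccc4o3)CC2)o1)c1ccccc1` keeps the shared core but carries benzamidomethyl in place of 4-hydroxyphenyl on an aromatic carbon. Going by the values given here, no measured step makes this exact change, and no measured compound carries the new group. The closest evidence comes from the steps that put hydroxy in place of another group, which both raise the number: a 4.3-fold higher number from compound 1 to compound 3 (0.63 log units; beyond the scatter) and a 5.0-fold higher number from compound 2 to compound 3 (0.70 log units; beyond the scatter). Replacing methyl with fluoro matters little by comparison: a 1.2-fold lower number from compound 1 to compound 2 (0.06 log units; within the scatter). Compound 4 no longer has the hydroxy group, so a modest step toward a lower number is expected, though with wide uncertainty. The estimated change in this assay is a 2.6-fold lower number from compound 3 to compound 4 (0.41 log units; beyond the scatter). For compound 4 the estimate is 100000 nM, with an expected range from 35000 nM to 280000 nM.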

Compound 4, half-maximal inhibitory concentration: 52700 nM
For compound 4 the middle estimate is 1.9-fold (0.28 log units) above the measured one; low and high end bracket the measured number.
By their numbers in this assay, from the lowest: compounds 2, 4 and 1 (each within the scatter of the next); then compound 3.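

In this assay, replacing 4-hydroxyphenyl with benzamidomethyl gives a 4.9-fold lower number from compound 3 to compound 4 (0.69 log units; beyond the scatter), so a group with an amide and a carbonyl can sit on this aromatic carbon without the higher number seen with compound 3. Compound 4 also stands level with the two other phenyl compounds, with a 1.0-fold higher number from compound 2 to compound 4 (0.00 log units; within the scatter) and a 1.1-fold lower number from compound 1 to compound 4 (0.06 log units; within the scatter), which shows that a phenyl ring bonded directly to this carbon is not needed to reach this range. Nothing available here explains these results.

The compounds shown leave open which part of benzamidomethyl counts, the amide or its benzene ring, and an acetamidomethyl or aminomethyl group on the same carbon would help separate the two. They also leave open whether a carboxylic acid on the phenyl ring would raise the number as the hydroxy group does.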